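The compounds below may be only part of what the source reports. "The series", "measured", "known", "first", "only" and "open" are said of these compounds alone.

Measured so far, in a functional assay on MDA-MB-468 cells (Homo sapiens) for inhibition, read by sulforhodamine B assay, with a stated time of 48 h; on this read-out higher numbers stand for lower toxicity in this test and lower numbers for higher toxicity in this test:

Compound 1, `COc1cc(-c2nn(-c3cccc(NC(=O)c4ccc(Cl)c(C(F)(F)F)c4)c3)cc2-c2ccncc2)ccc1Cl`, gives > 32500 nM, which is a limit of the assay and not a number.
Compound 2, `COc1cc(-c2nn(-c3cccc(NC(=O)c4cccc(C(F)(F)F)c4)c3)cc2-c2ccncc2)ccc1Cl`, gives > 50000 nM, again a limit of the assay rather than a number.
Compound 3, `COc1cc(-c2nn(-c3cccc(NC(=O)Nc4cccc(C(F)(F)F)c4)c3)cc2-c2ccncc2)ccc1Cl`, gives 50000 nM.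

Within the data shown here, compound 3 thus holds the only real number among the three values shown; the other two stand at limits, as stated in the limit of > 32500 nM in this assay, at which 1 of the 3 values shown sits, and (the limit of > 50000 nM in this assay, at which 1 of the 3 values shown sits).

Compound 4 is `COc1cc(-c2nn(-c3cccc(NC(=O)Nc4ccc(Cl)c(C(F)(F)F)c4)c3)cc2-c2ccncc2)ccc1Cl`. It differs from compound 3 by chloro in place of hydrogen on an aromatic carbon.

Two measured steps lead into compound 3 and bear on this. From compound 1 to compound 3 the step is a step that the limit leaves unreadable from compound 1 to compound 3. From compound 2 to compound 3 the step is a number no higher from compound 2 to compound 3 (the limit leaves the size open). The step from compound 1 to compound 2, a step that the two limits leave unreadable from compound 1 to compound 2, carries the same kind of change in the other direction, on the amide pair, and its size is likewise not readable. None of these steps gives a readable size, so no movement beyond the scatter is expected in this assay for the present change.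

Compound 4 is therefore expected to give about 50000 nM, within a range from 20000 nM to 100000 nM, with a fair chance that only a limit is reported. The expected step is no change at the digits printed from compound 3 to compound 4 (within the scatter).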

Compound 4, concentration lethal to 50% of the cells: > 32500 nM
Compound 4: only a limit was reported; the forecaster's own chance of this, stated with the estimate: 60%; the middle value is on the limit's open side.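

In this assay compound 4 gives > 32500 nM, which is a limit of the assay and not a number. Its steps from compound 1, compound 2 and compound 3 therefore cannot be read. The compounds shown leave open whether chloro in place of hydrogen moves the value in this assay at all.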